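Changing the Ring on the Amine Nitrogen of a Shared Core

The compounds below may be only part of what the source reports. "The series", "measured", "known", "first", "only" and "open" are said of these compounds alone.

Measured compounds:
compound 1, `Cc1ccc(S(=O)(=O)/N=C(/CCNC2=CC(=O)c3ccccc3C2=O)Nc2ccc(Cl)cc2)cc1`, 65400 nM
compound 2, `Cc1ccc(S(=O)(=O)/N=C(/CCNC2=CC(=O)c3ccccc3C2=O)Nc2ccccc2I)cc1`, 49400 nM
compound 3, `COc1ccc(N/C(CCNC2=CC(=O)c3ccccc3C2=O)=N\S(=O)(=O)c2ccc(C)cc2)cc1OC`, 60600 nM

In an ADME assay on HEK293 cells (Homo sapiens) for cytotoxicity, read by MTT assay, with a stated time of 48 h (on this read-out lower numbers stand for stronger inhibition and higher numbers for weaker inhibition), compound 1 gives 65400 nM, the largest of the three numbers, but compound 3 and compound 2 both sit within the scatter of it, so none of the three can be set apart from the others. The two steps that start from compound 1 tell the same story: a 1.3-fold lower number from compound 1 to compound 2 (0.12 log units; within the scatter) and a 1.1-fold lower number from compound 1 to compound 3 (0.03 log units; within the scatter). Neither ring swap on the amine nitrogen moved the number beyond the scatter.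

Compound 4, `Cc1ccc(S(=O)(=O)/N=C(/CCNC2=CC(=O)c3ccccc3C2=O)Nc2ccc(F)c(F)c2)cc1`, differs from compound 1 in one place: 3,4-difluorophenyl in place of 4-chlorophenyl on an amine nitrogen. It has not yet been measured in this assay. Since the two measured swaps at this position, to compound 2 and to compound 3, stayed within the scatter, the expectation for compound 4 is a step of about a 1.1-fold lower number from compound 1 to compound 4 (0.04 log units; within the scatter), that is, no change beyond the scatter. Compound 4 is therefore estimated at 60000 nM, with a range from 30000 nM to 120000 nM.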

Compound 4, half-maximal inhibitory concentration: 55200 nM
Beside the measured number, compound 4's estimate is 1.1-fold (0.04 log units) above it, and the stated range covers the measured number.
By their numbers in this assay, from the lowest: compounds 2, 4, 3 and 1 (each within the scatter of the next).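

In this assay, 3,4-difluorophenyl on the amine nitrogen adds a fourth ring to the series, and all three of its new steps lie within the scatter: a 1.2-fold lower number from compound 1 to compound 4 (0.07 log units; within the scatter), a 1.1-fold lower number from compound 3 to compound 4 (0.04 log units; within the scatter) and a 1.1-fold higher number from compound 2 to compound 4 (0.05 log units; within the scatter). The step from 3,4-dimethoxyphenyl to 3,4-difluorophenyl also shows that exchanging the two methoxy groups for two fluorine atoms on the ring leaves the number within the scatter, so all four compounds remain inseparable at this position. No available evidence accounts for this lack of separation.

Going by these compounds, all four compounds carry a substituted phenyl ring at this position, so the effect of a carboxylic acid on that ring remains open. The same is true of a cyclohexyl group or a benzyl group in its place.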